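A few compounds are considered here, and "the series" means these few. Any claim that something is new, unique, unknown or untested is made for them only; others in the source may bear on it.

Compound 1 (`Cc1ccc(Nc2nccc(Nc3ccc4nc[nH]c4c3)n2)cc1`) and compound 2 (`NS(=O)(=O)c1ccc(Nc2nccc(Nc3ccc4nc[nH]c4c3)n2)cc1`) share one core and differ in a single group. In an ADME assay on HepG2 cells (Homo sapiens) for inhibition, read by fluorescence and resazurin assay, with a stated time of 72 h (on this read-out higher numbers stand for weaker inhibition and lower numbers for stronger inhibition), compound 1 gives > 25000 nM, which is a limit of the assay and not a number. In this assay compound 2 gives > 25000 nM, again a limit, so this is all that can be said of where it stands. Compound 3 (`O=C(O)c1ccc(Nc2nccc(Nc3ccc4nc[nH]c4c3)n2)cc1`) keeps the shared core and carries carboxy in place of sulfamoyl on an aromatic carbon, para to a large group: carboxy in place of sulfamoyl on an aromatic carbon. Among the measured compounds shown here, the one measured step that bears on this change is a step that the two limits leave unreadable from compound 1 to compound 2, a swap on that same carbon, and it offers no size to carry over. What the data do show is the limit of > 25000 nM in this assay, at which 2 of the 2 values shown sit. Neither group that has occupied this carbon has yet produced a readable number in this assay, so no readable shift in either direction is expected. The estimated step that the limit leaves unreadable from compound 2 to compound 3 is expected to stay within the scatter, and the assay will most likely report another limit. For compound 3 the estimate is 30000 nM, expected to lie between 15000 nM and 60000 nM.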

Compound 3, half-maximal inhibitory concentration: > 25000 nM
Compound 3: only a limit was reported (the forecaster's own chance of this, stated with the estimate: 85%); the middle value lies beyond the limit too.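

Compound 3 joins compound 1 and compound 2 in giving only a limit in this assay, so no step among these three compounds can be read: the limit of > 25000 nM in this assay, at which 3 of the 3 values shown sit.

The compounds shown leave open whether any group on this aromatic carbon gives a readable value in this assay, and how methyl, sulfamoyl and carboxy truly compare.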